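Chloro to Fluoro on the Benzyl Arm of a Piperazine Amide

This account rests on a few compounds, and the source may have more. Where it says the series, first, only, none or still open, it means among the compounds named here.

Compound 1, `O=C(CN[C@H]1CCN(S(=O)(=O)Cc2ccccc2)C1)N1CCN(Cc2ccccc2Cl)CC1`: 9000 nM
Compound 2, `O=C(CN[C@H]1CCN(S(=O)(=O)Cc2ccccc2)C1)N1CCN(Cc2cccc(Cl)c2)CC1`: 8600 nM

In a functional assay on K562 cells (Homo sapiens) for cytotoxicity, read by MTT assay, with a stated time of 48 h (a lower number here means a stronger inhibitor, a higher number a weaker inhibitor), compound 1 gives 9000 nM and compound 2 gives 8600 nM. Going by the values given here, compound 2 holds the lowest of the two numbers, yet the only measured step, a 1.0-fold lower number from compound 1 to compound 2 (0.02 log units; within the scatter), shifts the chloro between aromatic carbons without changing the halogen, so it bears on the next step only loosely. Compound 3, `O=C(CN[C@H]1CCN(S(=O)(=O)Cc2ccccc2)C1)N1CCN(Cc2cccc(F)c2)CC1`, differs from compound 2 by fluoro in place of chloro on an aromatic carbon. Among the compounds with values here, no measured step swaps one halogen for another. Compound 3 is therefore expected to show a 1.0-fold higher number from compound 2 to compound 3 (0.02 log units; within the scatter), a step within the scatter, for an estimated 9000 nM ranging from 4500 nM to 18000 nM.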

Compound 3, half-maximal inhibitory concentration: 13200 nM
The estimate for compound 3 lay 1.5-fold (0.17 log units) below the measured number; the measured number falls inside the stated range.
By their numbers in this assay, from the lowest: compounds 2, 1 and 3 (each within the scatter of the next).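

In this assay, going by these compounds alone, fluoro in place of chloro on an aromatic carbon, the first exchange of one halogen for another here, gives a 1.5-fold higher number from compound 2 to compound 3 (0.19 log units; within the scatter) and so stays within the scatter at this place. Measured against the 2-chlorophenyl arm, the 3-fluorophenyl arm gives a 1.5-fold higher number from compound 1 to compound 3 (0.17 log units; within the scatter) and also stays within the scatter, so the three halogenated arms cannot be told apart in this assay. No evidence at hand bears on this result. The compounds shown leave open whether a methoxy or an amine at this place would move the number beyond the scatter.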